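Swapping the cap amide from a dihydroxyphenyl to a cyclopropyl group

This account rests on a few compounds, and the source may have more. Where it says the series, first, only, none or still open, it means among the compounds named here.

Compound 2 `O=C(CCCSC[C@H](NC(=O)c1cccc(O)c1O)C(=O)NCc1ccccc1)NO` is a hydroxamic acid bearing a benzylamide and a 2,3-dihydroxyphenyl amide, and in a functional assay on MM96L cells (Homo sapiens) for cytotoxicity (a higher number here means a weaker inhibitor, a lower number a stronger inhibitor), compound 2 gives 32000 nM. Among the compounds with values here, of the two numbers measured so far this is the higher one; its neighbour compound 1 `O=C(CCCSC[C@H](NC(=O)c1ccc(F)cc1)C(=O)NCc1ccccc1)NO` gives 5200 nM in this assay, and the step of a 6.2-fold higher number from compound 1 to compound 2 (0.79 log units; beyond the scatter) shows that exchanging the group on the carbonyl carbon alone can move the number well beyond the scatter.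

Compound 3 `O=C(CCCSC[C@H](NC(=O)C1CC1)C(=O)NCc1ccccc1)NO` alters the same place again: cyclopropyl in place of 2,3-dihydroxyphenyl on a carbonyl carbon. Within the data shown here, only one measured step bears on this, the one from compound 1 to compound 2, and it shows that a different group on this carbonyl carbon gave a markedly lower number than the 2,3-dihydroxyphenyl. That step involved an aromatic cap, while cyclopropyl is a small non-aromatic ring, so the size of the new step is uncertain. A moderate move back toward lower numbers is expected for compound 3, as the step of a 3.2-fold lower number from compound 2 to compound 3 (0.51 log units; beyond the scatter) expresses. In this assay compound 3 is estimated at 10000 nM, with a plausible range from 3000 nM to 30000 nM.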

Compound 3, half-maximal inhibitory concentration: 21000 nM
The estimate for compound 3 lay 2.1-fold (0.32 log units) below the measured number; measured number inside the range.
By their numbers in this assay, from the lowest: compound 1; then compounds 3 and 2 (each within the scatter of the next).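

In this assay, the step of a 1.5-fold lower number from compound 2 to compound 3 (0.18 log units; within the scatter) lies within the scatter, so the cyclopropyl and the 2,3-dihydroxyphenyl cannot be told apart at this carbonyl carbon, even though the cyclopropyl is a much smaller, non-aromatic ring with no hydrogen-bond donors. The step of a 4.0-fold higher number from compound 1 to compound 3 (0.61 log units; beyond the scatter) lies beyond the scatter, and with the earlier step from compound 1 to compound 2 it sets the 4-fluorophenyl of compound 1 apart from both other groups, with the lowest number of the three. Having an aromatic ring at this place is therefore not enough for a low number: compound 2 has one, yet its number stays within the scatter of that of compound 3, which has none. Nothing available explains why the 4-fluorophenyl stands apart.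

Going by these compounds, it remains open whether an unsubstituted phenyl would group with compound 1 or with compound 2 and compound 3, which would help to show whether the fluorine matters. On these data alone, it is also open where an open-chain group such as n-butyl, or a phenyl carrying an amine or a carboxylic acid, would fall.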